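From isopropyl to isobutyl on a ring amine

The source may report more compounds than this note shows. Statements on the series, on what has been measured and on what is new or still open speak of the compounds shown alone.

Compound 2 (`CC(C)N1CCc2c(sc(NC(=O)Nc3ccc(Cl)cc3)c2C(N)=O)C1`) gives 1490 nM in a functional assay (strain AB) with Danio rerio as the target, read by microscopy, with a stated time of 1 h (on this read-out higher numbers stand for an effect only at larger amounts of compound and lower numbers for an effect already at smaller amounts), and stands level with compound 1 (`NC(=O)c1c(NC(=O)Nc2ccc(Cl)cc2)sc2c1CCN(CC1CCCC1)C2`), which gives 1830 nM there. The two numbers lie within the scatter of each other, so neither compound can be placed ahead of the other.

Compound 3 (`CC(C)CN1CCc2c(sc(NC(=O)Nc3ccc(Cl)cc3)c2C(N)=O)C1`) keeps the core of compound 2 but carries isobutyl in place of isopropyl on an amine nitrogen in a ring, a change counted as isobutyl in place of isopropyl on an amine nitrogen in a ring and still unmeasured. Within the data shown here, the one measured step at that nitrogen is a 1.2-fold lower number from compound 1 to compound 2 (0.09 log units; within the scatter) and came with isopropyl in place of cyclopentylmethyl. Among the measured compounds shown here, no measured compound yet carries isobutyl, so the expectation rests on that single step alone. On this thin evidence, no step beyond the scatter is expected in this assay and no clear direction can be assigned. The estimated step of a 1.1-fold higher number from compound 2 to compound 3 (0.03 log units; within the scatter) is expected to stay within the scatter. Compound 3 is expected at 1600 nM in this estimate, with an estimated range from 800 nM to 3200 nM as its likely span.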

Compound 3, half-maximal effective concentration: 4510 nM
Beside the measured number, compound 3's estimate is 2.8-fold (0.45 log units) below it; measured number above the stated range.
By their numbers in this assay, from the lowest: compounds 2 and 1 (each within the scatter of the next); then compound 3.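

In this assay, among these compounds, the amine nitrogen in the ring no longer looks indifferent to its substituent: isobutyl in place of isopropyl brought a 3.0-fold higher number from compound 2 to compound 3 (0.48 log units; beyond the scatter), the first step at this nitrogen to lie beyond the scatter. Compound 3 also stands apart from the compound with the cyclopentyl group, since isopropyl in place of cyclopentyl on a saturated chain carbon bound to an amine nitrogen in a ring came with a 2.5-fold higher number from compound 1 to compound 3 (0.39 log units; beyond the scatter), so the difference is not confined to one comparison. The three compounds do not follow a simple order by the group's carbon count alone, as one carbon more on going from isopropyl to isobutyl raises the number, while compound 1, with its cyclopentylmethyl group, stays within the scatter of compound 2.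

The compounds shown leave open whether the higher number belongs to isobutyl alone or extends to other groups on this nitrogen, such as ethyl, an unbranched butyl chain or a plain hydrogen. Nothing available here accounts for the way isobutyl stands apart from the other two groups.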